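Moving the chlorine: from compound 1 to compound 3

The source may report more compounds than this note shows. Statements on the series, on what has been measured and on what is new or still open speak of the compounds shown alone.

Within the data shown here, in a functional assay on T47D cells (Homo sapiens) for cytotoxicity, read by CCK-8 assay and cell counting, with a stated time of 2 days (on this read-out lower numbers stand for stronger inhibition and higher numbers for weaker inhibition), compound 1 (`Oc1ccc(-c2cc(-c3ccc(Cl)cc3)nc(-c3ccsc3)c2)cc1`) gives 5490 nM, the lower of the two numbers so far, and compound 2 (`Oc1ccc(-c2cc(-c3ccc(Cl)cc3)nc(-c3ccccn3)c2)cc1`) gives 25900 nM. Compound 3 (`Oc1ccc(-c2cc(-c3ccsc3)nc(-c3cccc(Cl)c3)c2)cc1`) has 3-chlorophenyl in place of 4-chlorophenyl on an aromatic carbon. Among the measured compounds shown here, the only measured step, a 4.7-fold higher number from compound 1 to compound 2 (0.67 log units; beyond the scatter), puts pyridin-2-yl in place of thiophen-3-yl, a different change, so it sets no size for this one. No shift beyond the scatter is therefore expected, and the estimated step is a 1.2-fold lower number from compound 1 to compound 3 (0.09 log units; within the scatter). Compound 3 is expected at 4500 nM, with an estimated range of 1400 nM to 15000 nM.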

Compound 3, half-maximal inhibitory concentration: 7390 nM
Beside the measured number, compound 3's estimate is 1.6-fold (0.22 log units) below it, within the range that was stated.
By their numbers in this assay, from the lowest: compounds 1 and 3 (each within the scatter of the next); then compound 2.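

In this assay, moving the chlorine gives a 1.3-fold higher number from compound 1 to compound 3 (0.13 log units; within the scatter), so at this position, next to the ring nitrogen, 3-chlorophenyl and 4-chlorophenyl cannot be told apart. Among these compounds, the earlier step changed the thiophen-3-yl group, so this is the first reading of the chlorophenyl group itself, and it shows that this relocation of the chlorine leaves the number within the scatter. Nothing available explains this result. Still open, as far as these compounds go, is whether 2-chlorophenyl, or an amine or methoxy group in place of the chlorine, would shift the number beyond the scatter.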